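A Hydroxyalkyl Chain Takes the Place of an Aryl Group

The compounds below may be only part of what the source reports. "The series", "measured", "known", "first", "only" and "open" are said of these compounds alone.

Compound 1, `COc1nc2ccc(Br)cc2cc1C(c1ccccc1)n1cc(-c2ccc(Br)cc2)nn1`, gives 6.28% in an ADME assay on HEK293 cells (Homo sapiens) for cytotoxicity, read by sulforhodamine B assay, with a stated time of 48 h, tested at 10 uM; on this read-out higher numbers stand for more inhibition at the one concentration tested (going by the name of the read-out) and lower numbers for less inhibition.
Compound 2, `COc1nc2ccc(Br)cc2cc1C(c1ccccc1)n1cc(CCCO)nn1`, gives 27.4% in this assay.
Compound 3, `COc1nc2ccc(Br)cc2cc1C(c1ccccc1)n1cc(-c2ccccc2C(F)(F)F)nn1`, gives 14.3% in this assay.

Among these three, compound 3 stands second highest. Its nearest neighbour is compound 1, separated by a number 8 percentage points higher from compound 1 to compound 3 (within the scatter), so the two cannot be told apart. The furthest is compound 2, from which compound 3 is reached by a number 13.1 percentage points lower from compound 2 to compound 3 (beyond the scatter).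

Compound 4, `COc1nc2ccc(Br)cc2cc1C(c1ccccc1)n1cc(CCCCCO)nn1`, has not yet been tested in this assay. It differs from compound 3 in one place: 5-hydroxypentyl in place of 2-(trifluoromethyl)phenyl on an aromatic carbon.

Among the measured compounds shown here, two measured steps bear on this change, both replacing an aryl group by a hydroxyalkyl chain or the reverse. Going from compound 1 to compound 2 gave a number 21.1 percentage points higher from compound 1 to compound 2 (beyond the scatter), and going from compound 2 to compound 3 gave a number 13.1 percentage points lower from compound 2 to compound 3 (beyond the scatter). The step to compound 4 runs the second of these backwards, with a longer chain, so compound 4 is expected to move upward by roughly a number 11.7 percentage points higher from compound 3 to compound 4 (beyond the scatter). The estimate for compound 4 is therefore 26%, with a likely range from 12% to 40%.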

Compound 4, a percentage reported as inhibition, at one concentration (the size of the read-out at that concentration, not a potency): 7.96%
Compound 4: middle estimate off by 18 percentage points, on the high side, outside the stated range (below it).
By their numbers in this assay, from the lowest: compounds 1, 4 and 3 (each within the scatter of the next); then compound 2.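

In this assay, a hydroxyalkyl chain on this aromatic carbon does not by itself go with the higher number: the 5-hydroxypentyl group of compound 4 cannot be told apart from the 2-(trifluoromethyl)phenyl group (a number 6.3 percentage points lower from compound 3 to compound 4 (within the scatter)) or from the 4-bromophenyl group of compound 1 (a number 1.7 percentage points higher from compound 1 to compound 4 (within the scatter)). Among the compounds shown here, the two hydroxyalkyl compounds do separate, with a chain change alone giving the step (a number 19.4 percentage points lower from compound 2 to compound 4 (beyond the scatter)), so the length of the chain matters here in a way the earlier compounds could not show. Compound 2 is now the only one of the four that stands clear of all the others, and no measurement shown explains the gap between the two chains.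

The compounds shown leave open whether a 4-hydroxybutyl chain would fall with compound 2 or with compound 4, and so whether the change with length is gradual or confined to the 3-hydroxypropyl group. They also leave open whether the hydroxy end matters at all, which a plain propyl chain, or a propyl chain ending in an amine or a carboxylic acid, would address.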